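The compounds below may be only part of what the source reports. "The series", "measured", "known", "first", "only" and "open" are said of these compounds alone.

In a functional assay on A549 cells (Homo sapiens) for cytotoxicity (on this read-out higher numbers stand for weaker inhibition and lower numbers for stronger inhibition), compound 1 `Cc1ccc(S(=O)(=O)N2CC(c3ccc(Br)cc3)NC2=O)cc1` gives only a limit, > 253000 nM, and not a number. Compound 2 `O=C1NC(c2ccc(Br)cc2)CN1S(=O)(=O)c1ccc(Cl)cc1` gives 161000 nM, and compound 3 `Cc1ccc(S(=O)(=O)N2C(=O)NCC2c2ccc(Br)cc2)cc1` gives 67000 nM. Compound 4 `Cc1ccc(C2CN(S(=O)(=O)c3ccc(C)cc3)C(=O)N2)cc1` keeps the core of compound 1 and differs from it by methyl in place of bromo on an aromatic carbon, para to a large group.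

Within the data shown here, only one measured step bears on this change, and it sits at a different aromatic carbon, with chloro in place of methyl. That step is an at least 1.5-fold lower number from compound 1 to compound 2 (0.19 log units; that floor lies within the scatter). Its floor lies within the scatter, so it gives no firm size or direction for swapping a halogen and a methyl. No step beyond the scatter is therefore expected in this assay, and compound 4 may well return only a limit too. The estimated change is an at least 1.1-fold lower number from compound 1 to compound 4 (0.06 log units; that floor lies within the scatter). For compound 4 the expected value is 220000 nM, with an estimated range of 90000 nM to 500000 nM.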

Compound 4, half-maximal inhibitory concentration: > 302000 nM
Compound 4: no number, only a limit; the forecaster's own chance of this, stated with the estimate: 55%; middle value at least 1.3-fold (0.13 log units) away from the limit.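

In this assay, compound 1 and compound 4 each give only a limit and not a number, so the step between them cannot be read. The compounds shown leave open whether going from 4-bromophenyl to 4-methylphenyl changes the read-out at all, and by how much.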